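Fluoro for Methoxy: Expected Antiproliferative Potency of Compound 4

This account rests on a few compounds, and the source may have more. Where it says the series, first, only, none or still open, it means among the compounds named here.

Compound 1 `COc1ccc(-c2[nH]c3ccc(OC)cc3c2C=C(C#N)C#N)cc1`: 590 nM
Compound 2 `COc1ccc(-c2[nH]c3cc(OC)ccc3c2C=C(C#N)C#N)cc1`: 260 nM
Compound 3 `COc1ccc(-c2[nH]c3ccc(F)cc3c2C=C(C#N)C#N)cc1`: 400 nM

Three compounds were tested in a functional assay on MDA-MB-231 cells (Homo sapiens) for antiproliferative activity, with a stated time of 4 days; on this read-out higher numbers stand for weaker inhibition and lower numbers for stronger inhibition. Compound 1 and compound 2 are built from the same atoms joined differently; the difference between the two cores is not broken down here. On this assay compound 1 gives 590 nM and compound 2 gives 260 nM, a gap that lies beyond the scatter. Compound 3 is derived from compound 1 by one change, (fluoro in place of methoxy on an aromatic carbon), and this change gave a 1.5-fold lower number from compound 1 to compound 3 (0.17 log units; within the scatter).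

The unmeasured compound 4 `COc1ccc(-c2[nH]c3cc(F)ccc3c2C=C(C#N)C#N)cc1` is derived from compound 2 by the same change, (fluoro in place of methoxy on an aromatic carbon). Both place descriptions agree word for word. The expected step for this change is a 1.4-fold lower number from compound 2 to compound 4 (0.16 log units; within the scatter), set beside the earlier step because a 1.5-fold lower number from compound 1 to compound 3 (0.17 log units; within the scatter) stayed within the scatter, and because compound 2 starts from 260 nM. Compound 4 is therefore expected to give 180 nM in this assay, with a likely range of 90 nM to 360 nM.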

Compound 4, half-maximal inhibitory concentration: 280 nM
For compound 4 the middle estimate is 1.6-fold (0.19 log units) below the measured one, within the range that was stated.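

On the core of compound 2, fluoro in place of methoxy gave a 1.1-fold higher number from compound 2 to compound 4 (0.03 log units; within the scatter), a step that lies within the scatter. Set beside the same change on the core of compound 1, this step does not differ from the earlier one in this assay: the same change on two cores in this assay, a 1.5-fold lower number (0.17 log units; within the scatter) from compound 1 to compound 3 and a 1.1-fold higher number (0.03 log units; within the scatter) from compound 2 to compound 4, 1.6-fold (0.20 log units) apart, within the scatter of two such steps. The two cores therefore agree in that neither step lies beyond the scatter, but this is agreement between two small steps only: it does not show that a larger step would carry across, and it says nothing about any core beyond these two.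

The compounds shown leave open what other groups on this aromatic carbon, such as an amine or a carboxylic acid, would do to the antiproliferative read-out on either core. They also leave open whether a longer chain, such as ethoxy in place of methoxy, would give a step beyond the scatter.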